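From Ring to Open Chain in Compound 1

This account rests on a few compounds, and the source may have more. Where it says the series, first, only, none or still open, it means among the compounds named here.

Measured in a functional assay on HO8910 cells (Homo sapiens) for inhibition, read by MTT assay, with a stated time of 24 h, tested at 10 ug/mL (on this read-out higher numbers stand for more inhibition of growth at the one concentration tested and lower numbers for less inhibition of growth), so far:
compound 1 `O=C(CCCCC1CCSS1)Nc1ccccc1Cl` gives 4.66%
compound 2 `O=C(CCCCC1CCSS1)Nc1cccc(C(F)(F)F)c1` gives 5.99%
compound 3 `O=C(CCCCC1CCSS1)Nc1ccccn1` is reported as "not active" (no number reported)

Compound 1 stands with compound 2 at the bottom end of the possible range: their two numbers lie within the usual scatter of each other, so they cannot be ranked. Both numbers describe little effect on growth. Compound 3 has no number at all, so it cannot be placed exactly beside them.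

The next compound, compound 4 `O=C(CCCCC(S)CCS)Nc1ccccc1Cl`, keeps the core of compound 1 and changes one group (a group of 5 heavy atoms (3 carbon, 2 sulfur; no ring) in place of a group of 5 heavy atoms (3 carbon, 2 sulfur; one five-membered non-aromatic ring with 2 hetero atoms), on a saturated chain carbon, four bonds along the chain from a carbonyl carbon). The five-membered non-aromatic ring with 2 hetero atoms gives way to an open 1,3-disulfanylpropyl group, on a saturated chain carbon, four bonds along the chain from a carbonyl carbon.

Going by the values given here, no measured pair shows what such a change does, so the expectation is loose. It starts from compound 1 at 4.66% and leans slightly upward in this assay without a firm step beyond the scatter. The expected change is a number 5.3 percentage points higher from compound 1 to compound 4 (within the scatter) and is an estimate only. For compound 4 the estimated value is 10% with an expected range from 1% to 30% on this read-out.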

Compound 4, percent growth inhibition at one concentration: "not active" (no number reported)
Compound 4 has no reported number here; the estimate stays without a comparison.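

In this assay, going by these compounds alone, compound 4 is reported as not active, with no number; no step from compound 1 at 4.66% can be read. Nothing measured here offers an explanation for this result. The compounds shown leave open how far the open 1,3-disulfanylpropyl group, in place of the ring, shifts growth inhibition.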